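The source may hold more compounds than are shown below. What is called first, only, known or untested is meant among the compounds shown, and "the series" means these compounds.

Of the compounds shown here, three sharing one core have been measured in an assay on COS-1 cells for displacement of a labelled ligand from sodium-dependent dopamine transporter (Homo sapiens); on this read-out higher numbers stand for weaker inhibition and lower numbers for stronger inhibition. Compound 1 `CC(C)OC(=O)C1=C(c2ccc(Cl)c(Cl)c2)CCC1` gives 2600 nM. Compound 2 `O=C(OCCF)C1=C(c2ccc(Cl)c(Cl)c2)CCC1` gives 500 nM. Compound 3 `O=C(Oc1ccccc1)C1=C(c2ccc(Cl)c(Cl)c2)CCC1` gives 170 nM, the lowest of the three numbers, and its steps to both others are beyond the scatter: the step from compound 1 to compound 3 is a 15-fold lower number from compound 1 to compound 3 (1.18 log units; beyond the scatter), the step from compound 2 to compound 3 is a 2.9-fold lower number from compound 2 to compound 3 (0.47 log units; beyond the scatter), and the step from compound 1 to compound 2 is a 5.2-fold lower number from compound 1 to compound 2 (0.72 log units; beyond the scatter).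

Compound 4 `Cc1cccc(OC(=O)C2=C(c3ccc(Cl)c(Cl)c3)CCC2)c1` differs from compound 3 by methyl in place of hydrogen on an aromatic carbon. Among the measured compounds shown here, none of the measured steps touches this position; all three swap the whole group on the oxygen next to the carbonyl, whereas here a single carbon is added to the phenyl already present. For the measured compounds named here, the numbers so far therefore offer no direct guide, and the change is small. The expectation is that compound 4 gives 150 nM, within a range of 50 nM to 450 nM, meaning an expected step of a 1.1-fold lower number from compound 3 to compound 4 (0.05 log units; within the scatter), not beyond the scatter.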

Compound 4, inhibition constant: 60 nM
Compound 4: the middle estimate sits 2.5-fold (0.40 log units) above what was measured, within the range that was stated.
By their numbers in this assay, from the lowest: compound 4; then compound 3; then compound 2; then compound 1.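

Every earlier step replaced one whole group with another, whereas compound 4 shows that a small change to the phenyl itself still moves the number: methyl in place of hydrogen on an aromatic carbon, meta to a large group, gives a 2.8-fold lower number from compound 3 to compound 4 (0.45 log units; beyond the scatter) in this assay and is beyond the scatter. The 3-methylphenyl group also extends the lead over the other two groups, with an 8.3-fold lower number from compound 2 to compound 4 (0.92 log units; beyond the scatter) against 2-fluoroethyl and a 43-fold lower number from compound 1 to compound 4 (1.64 log units; beyond the scatter) against isopropyl. Nothing available explains why this single added carbon lowers the number.

On these data alone, it remains open whether a methyl on another carbon of the ring would do the same, or whether ethyl, methoxy or an amine at this place would go further. As far as these compounds go, all four compounds share one core, so whether the methyl step carries over to a different core also remains open.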